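The compounds below may be only part of what the source reports. "The series", "measured", "known", "first", "only" and "open" are said of these compounds alone.

Measured compounds:
compound 1, `NCCn1ncc2c(NCc3ccccc3[N+](=O)[O-])cc(C(F)(F)F)cc21`: > 100000 nM
compound 2, `O=[N+]([O-])c1ccc(Cl)cc1CNc1cc(C(F)(F)F)cc2[nH]ncc12`: 3190 nM

In an assay for inhibition of Tryptophan 2,3-dioxygenase (Homo sapiens), with stated times of 10 min and 60 min (a lower number here means a stronger inhibitor, a higher number a weaker inhibitor), compound 1 gives only a limit, > 100000 nM. Compound 2 differs from compound 1 in several places. In this assay compound 2 gives 3190 nM. Where compound 1 stands is therefore known only as the limit of > 100000 nM in this assay, at which 1 of the 2 values shown sits, not as a number. For the measured compounds named here, no two measured compounds differ in a single place, so no step of measured size is available.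

Compound 3, `CC(C)n1ncc2c(NCc3ccccc3[N+](=O)[O-])cc(C(F)(F)F)cc21`, has not yet been measured. It differs from compound 1 by isopropyl in place of 2-aminoethyl on an aromatic nitrogen. Going by the values given here, with no measured step to lean on, a gain beyond the scatter is expected for this change, though the assay may again report only a limit. Compound 3 is expected to come in at 20000 nM, in a range from 3000 nM to 100000 nM. This corresponds to an expected step of an at least 5.0-fold lower number from compound 1 to compound 3 (0.69 log units; beyond the scatter).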

Compound 3, half-maximal inhibitory concentration: > 100000 nM
Compound 3 gave a limit, no number (the forecaster's own chance of this, stated with the estimate: 40%); middle value at least 5.0-fold (0.69 log units) away from the limit.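

No step can be read from compound 1 to compound 3, because in this assay both compounds give only a limit: the limit of > 100000 nM in this assay, at which 2 of the 3 values shown sit.

The compounds shown leave open whether isopropyl in place of 2-aminoethyl on the aromatic nitrogen changes the strength of inhibition at all.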